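The source may report more compounds than this note shows. Statements on the series, on what has been measured and on what is new or still open speak of the compounds shown alone.

In a functional assay on A549 cells (Homo sapiens) for cytotoxicity, read by MTT assay, with a stated time of 24 h (on this read-out lower numbers stand for stronger inhibition and higher numbers for weaker inhibition), compound 1 `CCOC(=O)N1CCC(=NNC(=O)c2ccc(F)cc2)CC1` gives only a limit of the assay rather than a number, > 400000 nM. Compound 2 `O=C(NN=C1CC(c2ccccc2)NC(c2ccccc2)C1)c1ccccc1` likewise reaches only a limit in this assay, > 400000 nM, and so stands at the limit of > 400000 nM in this assay, at which 2 of the 2 values shown sit. Compound 3 `O=C(NN=C1CC(c2ccccc2)NC(c2ccccc2)C1)c1ccc(Cl)cc1` differs from compound 2 by a single change, chloro in place of hydrogen on an aromatic carbon. For the measured compounds named here, no measured pair shows what this change does here, so the expected step of a number no higher from compound 2 to compound 3 (the limit leaves the size open) is none beyond the scatter. Compound 3 is thus expected at 400000 nM, within 100000 nM to 2000000 nM, and will most likely again be reported only as a limit.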

Compound 3, half-maximal inhibitory concentration: > 400000 nM
Compound 3 gave a limit, no number; the forecaster's own chance of this, stated with the estimate: 80%; the middle value sits exactly at the limit.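

No step from compound 2 to compound 3 can be read, because both give only a limit rather than a number in this assay: the limit of > 400000 nM in this assay, at which 3 of the 3 values shown sit.

The compounds shown leave open whether chloro in place of hydrogen on an aromatic carbon has any effect on the read-out.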